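Removing the methyl from compound 3: what to expect

The source may report more compounds than this note shows. Statements on the series, on what has been measured and on what is new or still open speak of the compounds shown alone.

Measured compounds:
compound 1 `Cc1[nH]ncc1-c1ccc2nc(C3COc4ccccc4C3)oc2c1` — 9 nM
compound 2 `COC(=O)c1ccc2c(c1)CC(c1nc3ccc(-c4ccnc(N)n4)cc3o1)CO2` — 24 nM
compound 3 `Cc1ccc2c(c1)CC(c1nc3ccc(-c4ccnc(N)n4)cc3o1)CO2` — 78 nM

Going by the values given here, in an assay on isolated protein for inhibition of Rho-associated protein kinase 2 (Homo sapiens) (a lower number here means a stronger inhibitor, a higher number a weaker inhibitor), compound 3 gives the highest number of the three: compound 2 sits at 24 nM, and the single step between them, a 3.3-fold higher number from compound 2 to compound 3 (0.51 log units; beyond the scatter), shows that methyl in place of methoxycarbonyl weakened inhibition. Compound 1, which carries no substituent on that ring but a different headgroup, gives 9 nM.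

Compound 4 `Nc1nccc(-c2ccc3nc(C4COc5ccccc5C4)oc3c2)n1` differs from compound 3 by hydrogen in place of methyl on an aromatic carbon. Among the compounds with values here, no measured step tests this change directly; only the methoxycarbonyl-to-methyl step touches the same position, and it was modest. A shift of similar or smaller size is therefore expected, with the direction uncertain, so compound 4 is estimated at 60 nM (range 20 nM to 200 nM), a step of a 1.3-fold lower number from compound 3 to compound 4 (0.11 log units; within the scatter).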

Compound 4, half-maximal inhibitory concentration: 27 nM
Compound 4: middle estimate off by 2.2-fold (0.35 log units), on the high side; measured number inside the range.
By their numbers in this assay, from the lowest: compound 1; then compounds 2 and 4 (each within the scatter of the next); then compound 3.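

In this assay, taking the methyl off this aromatic carbon strengthens inhibition by a step beyond the scatter (a 2.9-fold lower number from compound 3 to compound 4 (0.46 log units; beyond the scatter)), while hydrogen and methoxycarbonyl cannot be told apart here (a 1.1-fold higher number from compound 2 to compound 4 (0.05 log units; within the scatter)), so methyl stands apart from both groups. With hydrogen on this carbon, the headgroup still matters (a 3.0-fold higher number from compound 1 to compound 4 (0.48 log units; beyond the scatter)), with 2-aminopyrimidin-4-yl in place of 5-methyl-1H-pyrazol-4-yl. No supporting data explain the effect of the methyl.

As far as these compounds go, whether an amine or a carboxylic acid on this carbon would side with methyl or with hydrogen remains open. So does whether removing the methyl has a similar effect with the 5-methyl-1H-pyrazol-4-yl headgroup.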